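Replacing the triazole arm of compound 1 with an amino-oxadiazole

The compounds below may be only part of what the source reports. "The series", "measured", "known", "first", "only" and "open" are said of these compounds alone.

Compound 1 `CSc1nnc(Cc2ccc(Cl)cc2Oc2ccccc2Cl)[nH]1` gives 170% in a functional assay on the whole organism (strain NMRI) with Mus musculus as the target, with a stated time of 60 min, at a dose of 20 mg/kg by the intraperitoneal route (a lower number here means a weaker effect, a higher number a stronger effect of the compound at the dose given), and stands highest of the three measured numbers. Compound 3 `CSc1nnc(Cc2ccc(Cl)cc2Oc2ccccc2F)[nH]1` gives 136%, and compound 2 `Clc1ccc(Cc2nnc(SCc3ccccc3)[nH]2)c(Oc2ccccc2Cl)c1` gives 129%. The step to compound 4 `Nc1nnc(Cc2ccc(Cl)cc2Oc2ccccc2Cl)o1` is a group of 6 heavy atoms (2 carbon, 3 nitrogen, 1 oxygen; one five-membered aromatic ring with 3 hetero atoms) in place of a group of 7 heavy atoms (3 carbon, 3 nitrogen, 1 sulfur; one five-membered aromatic ring with 3 hetero atoms), on a saturated chain carbon bound to an aromatic carbon. Neither measured step touches this part of the molecule: a number 41 percentage points lower from compound 1 to compound 2 (beyond the scatter) and a number 34 percentage points lower from compound 1 to compound 3 (beyond the scatter) both concern other positions. Within the data shown here, they show only that the two changes tried so far from compound 1 each lowered the read-out by a large margin. On that basis a drop beyond the scatter is expected for compound 4, with wide uncertainty, a number 50 percentage points lower from compound 1 to compound 4 (beyond the scatter). Compound 4 is estimated at 120%, within 60% to 180%.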

Compound 4, a percentage reported as activity, at one dose (the size of the read-out at that dose, not a potency): 170%
The estimate for compound 4 lay 50 percentage points below the measured number, and the stated range covers the measured number.
By their numbers in this assay, from the lowest: compounds 2 and 3 (each within the scatter of the next); then compounds 1 and 4 (each within the scatter of the next).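

In this assay, exchanging the leaving ring for 5-amino-1,3,4-oxadiazol-2-yl gives no change at the digits printed from compound 1 to compound 4 (within the scatter) and so, unlike the two changes elsewhere in compound 1, costs nothing in the read-out at this dose. The sulfur-bearing ring is therefore not required for this read-out, at least in this pair. Nothing measured here explains why the two rings read alike. Still open, going by these compounds, is whether a carboxylic acid or a tetrazole on the same saturated chain carbon would keep the read-out, and whether a dimethylamino group could replace the amino group on the oxadiazole.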